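This account rests on a few compounds, and the source may have more. Where it says the series, first, only, none or still open, it means among the compounds named here.

Of the compounds shown here, three from one series have been tested in a functional assay on the whole organism (Abdomen, strain Swiss albino) for inhibition, with Mus musculus as the target, in the writhing test, with a stated time of 30 min, at a dose of 30 mg/kg by the oral route; on this read-out lower numbers stand for less inhibition and higher numbers for more inhibition at the one dose given (going by the name of the read-out). Compound 1 `O=C(O)[C@H]1CCC[C@@H](c2cccc3ccccc23)O1` gives 49%. Compound 2 `OC[C@H]1CCC[C@@H](c2cccc3ccccc23)O1` gives 39.2%. Compound 3 `OC[C@H]1C[C@@H](Cl)C[C@@H](c2ccc3ccccc3c2)O1` gives 46.6%. The difference between the core of compound 2 and the core of compound 3 is not broken down here.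

Between compound 2 and compound 1 the structural change is carboxy in place of hydroxymethyl on a saturated ring carbon, and the measured step is a number 9.8 percentage points higher from compound 2 to compound 1 (within the scatter).

Compound 4 `O=C(O)[C@H]1C[C@@H](Cl)C[C@@H](c2ccc3ccccc3c2)O1` has not been measured yet. Within the data shown here, it arises from compound 3 by carboxy in place of hydroxymethyl on a saturated ring carbon, the same kind of change as the one from compound 2 to compound 1, though here the carbon carrying the new group is also two ring bonds from the ring atom that bears a chloro group, which is absent in the earlier pair.

Among the measured compounds shown here, for compound 4 a step of about a number 6.4 percentage points higher from compound 3 to compound 4 (within the scatter) in this assay is expected, resting on the one earlier step from compound 2 to compound 1. Compound 4 is therefore estimated to give 53%, with a likely range from 40% to 66%.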

Compound 4, a percentage reported as inhibition, in the whole organism at one dose (the size of the read-out at that dose, not a potency): 28.1%
Estimate against measurement, compound 4: 24.9 percentage points above; measured number outside the range, below it.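

In this assay, carboxy in place of hydroxymethyl on the core of compound 3 gives a number 18.5 percentage points lower from compound 3 to compound 4 (beyond the scatter), so the same change does not give the same result on both cores: the same change on two cores in this assay, a number 9.8 percentage points higher (within the scatter) from compound 2 to compound 1 and a number 18.5 percentage points lower (beyond the scatter) from compound 3 to compound 4, 28.3 percentage points apart, beyond the scatter of two such steps

A step measured on one core therefore cannot simply be carried over to another core in this series, and here even its direction differs. These two pairs do not show which feature of the cores makes the difference, as the chloro group is only one of the ways in which the core of compound 3 differs from the core of compound 2, and two pairs cannot establish a general rule for the series.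

The compounds shown leave open whether the lower number for compound 4 goes with the chloro group or with another part of its core. They also leave open how a methyl ester or an amide in place of the carboxy would read out in this assay on either core.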